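Ethyl in place of carboxy on the shared core

The source may report more compounds than this note shows. Statements on the series, on what has been measured and on what is new or still open speak of the compounds shown alone.

Measured so far:
compound 1 `[O-][n+]1ccc(Cl)c(Oc2ccccc2)c1` — > 300 mg/kg
compound 2 `O=C(O)c1cc[n+]([O-])cc1Oc1ccccc1` — > 300 mg/kg

In a functional assay on the whole organism with Mus musculus as the target, in the maximal electroshock model, with a stated time of 30 min (on this read-out lower numbers stand for an effect already at smaller amounts and higher numbers for an effect only at larger amounts of compound), compound 1 gives > 300 mg/kg, which is a limit of the assay and not a number. Compound 2 gives > 300 mg/kg in this assay, again a limit rather than a number. Compound 2 thus stands at the limit of > 300 mg/kg in this assay, at which 2 of the 2 values shown sit, and no number is known for it. The step that the two limits leave unreadable from compound 1 to compound 2 cannot be sized, as both of its ends are limits.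

Compound 3 `CCc1cc[n+]([O-])cc1Oc1ccccc1` differs from compound 2 by ethyl in place of carboxy on an aromatic carbon. Within the data shown here, the only measured step that bears on this position is a step that the two limits leave unreadable from compound 1 to compound 2, and its size is not readable; no measured compound carries ethyl at all. Nothing in the measured values therefore points to a direction for this step, and the data give no ground to expect a change beyond the scatter in this assay.

Compound 3 is expected near 300 mg/kg, with the range 100 mg/kg to 600 mg/kg carrying wide uncertainty. The expected step of a number no higher from compound 2 to compound 3 (the limit leaves the size open) is estimated as no change in this assay, with a high chance that only a limit is again recorded.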

Compound 3, minimum effective dose: 30 mg/kg
Compound 3: middle estimate off by 10-fold (1.00 log units), on the high side, outside the stated range (below it).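

In this assay, the place opposite the ring nitrogen now gives its first readable change: ethyl in place of carboxy on an aromatic carbon gives an at least 10-fold lower number from compound 2 to compound 3 (1.00 log units; beyond the scatter). Ethyl in place of chloro at the same place gives an at least 10-fold lower number from compound 1 to compound 3 (1.00 log units; beyond the scatter), so this position can respond in this read-out even though the step between compound 1 and compound 2 cannot be read, and both new steps remain open-ended in size since each starts from a limit. Only compound 3 carries a number in this assay, and compound 1 and compound 2 stay at a limit of the assay: the limit of > 300 mg/kg in this assay, at which 2 of the 3 values shown sit.

The compounds shown leave open whether ethyl is special at this place or whether methyl, a longer chain such as propyl, or an amine would also give a number in this assay. They also leave open whether the same change holds when the group of 7 heavy atoms ortho to this place is altered, and they do not tell why ethyl differs from carboxy and chloro.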